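A Second Methoxy Group Added to Compound 1

The compounds below may be only part of what the source reports. "The series", "measured", "known", "first", "only" and "open" are said of these compounds alone.

Measured compounds:
compound 1 `COc1ccc(-c2cc(/C=C/C(=O)c3ccc(N)cc3)[nH]n2)cc1`: 18000 nM
compound 2 `COc1ccc(C(=O)/C=C/c2cc(-c3cc(OC)c(OC)c(OC)c3)n[nH]2)cc1`: 20500 nM

In a functional assay on SK-OV-3 cells (Homo sapiens) for inhibition, read by sulforhodamine B assay, with a stated time of 48 h (on this read-out higher numbers stand for weaker inhibition of growth and lower numbers for stronger inhibition of growth), compound 1 gives 18000 nM. Compound 2 gives 20500 nM in this assay. Of the two numbers, that of compound 1 is the smaller, but compound 2 lies within the usual scatter of it, so the two compounds cannot be told apart on these data.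

Compound 3 `COc1ccc(-c2cc(/C=C/C(=O)c3ccc(N)cc3)[nH]n2)cc1OC` is not yet measured. It differs from compound 1 by methoxy in place of hydrogen on an aromatic carbon. Within the data shown here, no pair of measured compounds differing in a single place is available, so the size of such a change cannot be read from the data here. With nothing to point in either direction, the step from compound 1 to compound 3 is expected to stay within the scatter, in either direction. Compound 3 is therefore estimated at 15000 nM, with a range from 5000 nM to 45000 nM. This estimate means an expected step of a 1.2-fold lower number from compound 1 to compound 3 (0.08 log units; within the scatter).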

Compound 3, concentration for total growth inhibition: 16800 nM
Estimate against measurement, compound 3: 1.1-fold (0.05 log units) below, and the stated range covers the measured number.
By their numbers in this assay, from the lowest: compounds 3, 1 and 2 (each within the scatter of the next).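

Among these compounds, the first step that can be read at this position is methoxy in place of hydrogen on an aromatic carbon, ortho to a methoxy group and meta to a large group. In this assay this is a 1.1-fold lower number from compound 1 to compound 3 (0.03 log units; within the scatter), so the added methoxy leaves compound 3 indistinguishable from compound 1 on this read-out. No supporting data at hand bear on this result.

As far as these compounds go, whether another group at the same place, such as hydroxyl, fluorine or an amine, would also stay within the scatter remains open. So does whether a step of this size would hold on the core of compound 1 if its amine were exchanged for a carboxylic acid.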